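The compounds below may be only part of what the source reports. "The series", "measured", "known", "first", "only" and "open" are said of these compounds alone.

For the measured compounds named here, in an ADME assay on MRC5 cells (Homo sapiens) for cytotoxicity, read by fluorescence and resazurin assay, with a stated time of 3 days (a lower number here means a stronger inhibitor, a higher number a weaker inhibitor), the only number in this small series belongs to compound 1 `COc1ccc(Oc2cccc(CN3CCC(n4cc(C)c(=O)[nH]c4=O)CC3)c2)cc1`, which gives 28000 nM. Compound 2 `Cc1cn(C2CCN(Cc3cccc(Oc4ccncc4)c3)CC2)c(=O)[nH]c1=O` has no number to stand on: its entry reads "not determined" (no result reported), so it cannot be ranked against compound 1. The next structure, compound 3 `Cc1cn(C2CCN(Cc3cccc(Oc4ccc(Cl)c(C(F)(F)F)c4)c3)CC2)c(=O)[nH]c1=O`, differs from compound 2 in one place: 4-chloro-3-(trifluoromethyl)phenyl in place of pyridin-4-yl on an oxygen on an aromatic ring. Here 4-chloro-3-(trifluoromethyl)phenyl stands in place of pyridin-4-yl on an oxygen on an aromatic ring. Going by the values given here, no measured step shows what such a swap does, so the size of the move in this assay remains a judgement. A modest shift towards a lower number, meaning a somewhat stronger effect on the cells, is expected when set against compound 1 at 28000 nM. For compound 3 the estimated value is 15000 nM, with an expected range from 5000 nM to 45000 nM.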

Compound 3, half-maximal inhibitory concentration: 5280 nM
Beside the measured number, compound 3's estimate is 2.8-fold (0.45 log units) above it, within the range that was stated.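

In this assay, for the compounds shown here, putting 4-chloro-3-(trifluoromethyl)phenyl in place of 4-methoxyphenyl on an oxygen on an aromatic ring gives a 5.3-fold lower number from compound 1 to compound 3 (0.72 log units; beyond the scatter), the only step that can be read. It shows that the group carried on this oxygen can move the number beyond the usual scatter, which a single value could not show. Nothing at hand accounts for the size of this step.

The change from pyridin-4-yl cannot be read, as compound 2 has no value to start from, and this single step cannot separate the share of the chlorine from that of the trifluoromethyl group. As far as these compounds go, it also remains open how a phenyl ring carrying only chlorine, only trifluoromethyl, or instead a carboxylic acid would read at this position.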